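The source may report more compounds than this note shows. Statements on the series, on what has been measured and on what is new or still open speak of the compounds shown alone.

Measured so far in a functional assay on HCT-116 cells (Homo sapiens) for cytotoxicity, read by MTT assay, with a stated time of 72 h; a higher number here means a weaker inhibitor, a lower number a stronger inhibitor:

- Compound 1 `COc1ncc(-c2ccc3nc(NC(=O)NCCN4CCCC4)nn3c2)cc1NS(=O)(=O)c1ccc(F)cc1`: 230 nM
- Compound 2 `COc1ncc(-c2ccc3nc(NC(=O)NC4CC4)nn3c2)cc1NS(=O)(=O)c1ccc(F)cc1`: 90 nM

Of these two compounds, compound 2 has the lower number, 90 nM, which makes it the stronger inhibitor of the pair. The next compound to test is compound 3 `COc1ncc(-c2ccc3nc(NC(=O)NCCN4CCN(C)CC4)nn3c2)cc1NS(=O)(=O)c1ccc(F)cc1`, which puts 2-(4-methylpiperazin-1-yl)ethyl in place of cyclopropyl on an amide-type nitrogen.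

For the measured compounds named here, only one measured step bears on this change. That step is a 2.6-fold lower number from compound 1 to compound 2 (0.41 log units; beyond the scatter), and it came from placing cyclopropyl where compound 1 carries 2-(pyrrolidin-1-yl)ethyl. It is modest but beyond the scatter. Compound 3 makes nearly the reverse swap, with a six-membered non-aromatic ring with 2 hetero atoms in place of the pyrrolidine ring, so a rise of similar size is the natural expectation. Going by the values given here, a single step is thin evidence, and no measured compound yet carries the new ring, so the range must stay wide.

In this assay the expected step is a 2.4-fold higher number from compound 2 to compound 3 (0.39 log units; beyond the scatter). For compound 3 the estimated value is 220 nM, with an expected range of 90 nM to 550 nM.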

Compound 3, half-maximal inhibitory concentration: 260 nM
Estimate against measurement, compound 3: 1.2-fold (0.07 log units) below; measured number inside the range.
By their numbers in this assay, from the lowest: compound 2; then compounds 1 and 3 (each within the scatter of the next).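

In this assay, the step is a 2.9-fold higher number from compound 2 to compound 3 (0.46 log units; beyond the scatter). It agrees with the earlier step between compound 1 and compound 2, where cyclopropyl also gave the lower number, so compound 2, with its small cyclopropyl on the amide-type nitrogen, now has a lower number than two different compounds carrying a ring at the end of an ethyl chain. For the compounds shown here, what the earlier compounds could not show is that the ring at the end of that chain makes little difference here: exchanging pyrrolidin-1-yl for 4-methylpiperazin-1-yl gives a 1.1-fold higher number from compound 1 to compound 3 (0.05 log units; within the scatter) and so leaves compound 1 and compound 3 indistinguishable in this assay, even though the new ring brings a second nitrogen and a methyl group. Nothing measured on these compounds gives a reason for either result.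

Cyclopropyl differs from both other groups in ring and chain at once, so these three compounds cannot separate the effect of the ethyl chain from that of the ring at its end. A plain ethyl group, a cyclobutyl ring or a 2-(morpholin-4-yl)ethyl chain at this nitrogen would each bear on that question, and the compounds shown include none of them.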